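The source may report more compounds than this note shows. Statements on the series, on what has been measured and on what is new or still open speak of the compounds shown alone.

Within the data shown here, compound 1 `ClCc1ccccc1Cn1cnc2ncnc(Cl)c21` is the one compound with a number here: in a functional assay on SK-MEL-28 cells (Homo sapiens) for cytotoxicity, read by sulforhodamine B assay, with a stated time of 48 h (on this read-out lower numbers stand for higher toxicity in this test and higher numbers for lower toxicity in this test), compound 1 gives 79400 nM, a weak effect. From the compounds shown here alone, compound 2 `ClCc1ccc(Cn2cnc3ncnc(Cl)c32)cc1` is an isomer of compound 1 with the same atoms arranged differently, and in this assay compound 2 is reported as "not determined" (no result reported), so its standing is unknown. Compound 3 `ClCc1ccc(Cn2cnc3nc(Cl)nc(Cl)c32)cc1` arises from compound 2 by chloro in place of hydrogen on an aromatic carbon. Among the measured compounds shown here, no measured step of this kind is available, so in this assay a change of modest size is expected, in either direction, possibly within the scatter. Compound 3 is expected to give about 50000 nM, between 10000 nM and 150000 nM.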

Compound 3, concentration lethal to 50% of the cells: > 100000 nM
Compound 3: no number, only a limit; the forecaster's own chance of this, stated with the estimate: 25%; middle value at least 2.0-fold (0.30 log units) from the limit.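

Among these compounds, compound 2 has no result, so no step from compound 2 to compound 3 can be read. Compound 3 gives > 100000 nM, which is a limit and not a number. From the compounds shown here alone, how the added chloro changes the result in this assay stays open.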